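The source may report more compounds than this note shows. Statements on the series, on what has been measured and on what is new or still open speak of the compounds shown alone.

Of the compounds shown here, three built on one shared core have been measured, and a fourth is still to be tested. Compound 1 `Cc1ccccc1C[C@H]1C(=O)OC[C@@H]1Cc1ccccc1` gives 57000 nM in a functional assay on HL-60 cells (Homo sapiens) for cytotoxicity, read by WST assay, with a stated time of 48 h; on this read-out lower numbers stand for an effect already at smaller amounts and higher numbers for an effect only at larger amounts of compound. Compound 2 `O=C1OC[C@H](Cc2ccccc2)[C@H]1Cc1ccccc1F` differs from compound 1 in a single place, (fluoro in place of methyl on an aromatic carbon). In this assay compound 2 gives 72000 nM, so the change brought a 1.3-fold higher number from compound 1 to compound 2 (0.10 log units; within the scatter), which is a step too small to count as a real shift between the two compounds. Compound 3 `Cc1ccccc1C[C@H]1COC(=O)[C@@H]1Cc1ccc(Cl)c(Cl)c1` differs from compound 1 in more than one place; the difference between the two cores is not broken down here. In this assay compound 3 gives 22000 nM, the lowest of the three numbers, with compound 1 standing nearest to it and compound 2 furthest away, both gaps beyond the usual scatter.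

Compound 4 `O=C1OC[C@H](Cc2ccccc2F)[C@H]1Cc1ccc(Cl)c(Cl)c1` is the compound not yet measured. It differs from compound 3 by fluoro in place of methyl on an aromatic carbon, the same change, at the same kind of place on the ring, as that from compound 1 to compound 2. Because that earlier change gave a 1.3-fold higher number from compound 1 to compound 2 (0.10 log units; within the scatter), the expected step here is of similar size, a 1.3-fold higher number from compound 3 to compound 4 (0.10 log units; within the scatter), resting on a single measured pair. On that basis compound 4 is expected to give about 28000 nM in this assay, most likely between 14000 nM and 56000 nM.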

Compound 4, half-maximal effective concentration: 28000 nM
Compound 4: middle estimate and measured number agree at the digits printed; measured number inside the range.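

Replacing methyl with fluoro, which turns a 2-methylphenyl group into a 2-fluorophenyl group, gave in this assay a 1.3-fold higher number from compound 3 to compound 4 (0.10 log units; within the scatter), and this step matches the earlier one made on the core of compound 1: the same change on two cores in this assay, a 1.3-fold higher number (0.10 log units; within the scatter) from compound 1 to compound 2 and a 1.3-fold higher number (0.10 log units; within the scatter) from compound 3 to compound 4, 1.0-fold (0.00 log units) apart, within the scatter of two such steps

Across these two cores, then, the change carried over in the same way, leaving the number within the usual scatter both times. This agreement has limits: it is a match between two steps too small to count as real shifts, not between two clear effects, and two pairs say nothing about how the change would behave on a third core or in a different test.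

The compounds shown carry only methyl or fluoro at this place on the ring, so it remains open what a chloro group, a methoxy group, a trifluoromethyl group, an amine or a carboxylic acid would do there. From the compounds shown here alone, it also remains open whether any such group would move the number beyond the scatter on either core, and whether the two cores would then still respond alike.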